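A Second Aryl Group on the Shared Core

A few compounds are considered here, and "the series" means these few. Any claim that something is new, unique, unknown or untested is made for them only; others in the source may bear on it.

Measured compounds:
Compound 1 `CC(C)(C)Cc1csc(N)c1C(=O)c1ccc(Cl)cc1`: 1%
Compound 2 `Cc1sc(N)c(C(=O)c2ccc(Cl)cc2)c1-c1ccccc1`: 1%
Compound 3 `Nc1sc(-c2ccccc2)c(-c2ccccc2)c1C(=O)c1ccc(Cl)cc1`: 1%

Of the compounds shown here, three have been tested in an assay on CHO cells for displacement of a labelled ligand from adenosine receptor A1 (Homo sapiens), read by scintillation counting, tested at 10 uM; on this read-out lower numbers stand for less inhibition and higher numbers for more inhibition at the one concentration tested (going by the name of the read-out). In this assay compound 1 gives 1%, and compound 2 gives 1%, while compound 3 gives 1%. Compound 1 thus stands level with compounds 2 and 3 within the scatter, and all three sit at the floor of the read-out. Among these, one pair differs in a single place, phenyl in place of methyl on an aromatic carbon, and that step gave no change at the digits printed from compound 2 to compound 3 (within the scatter).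

Compound 4 `CC(C)(C)Cc1c(-c2cc(F)ccc2F)sc(N)c1C(=O)c1ccc(Cl)cc1` has not been measured. It differs from compound 1 in one place: 2,5-difluorophenyl in place of hydrogen on an aromatic carbon. Among the measured compounds shown here, the only measured step that bears on this, adding a phenyl ring onto the shared core, was flat, so no movement beyond the scatter is expected from this change either. Compound 4 is therefore expected to give 2% in this assay, with a range from -8% to 12%. The expected step is a number 1 percentage points higher from compound 1 to compound 4 (within the scatter).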

Compound 4, a percentage reported as inhibition, at one concentration (the size of the read-out at that concentration, not a potency): 3%
Compound 4: middle estimate off by 1 percentage points, on the low side, within the range that was stated.
By their numbers in this assay, from the lowest: compounds 1, 2, 3 and 4 (each within the scatter of the next).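

In this assay, putting 2,5-difluorophenyl in place of hydrogen on the aromatic carbon next to the ring sulfur gives a number 2 percentage points higher from compound 1 to compound 4 (within the scatter) and leaves the read-out at its floor. The earlier step only exchanged methyl for phenyl, whereas this one starts from hydrogen and adds a ring of 8 heavy atoms, next to the ring atom that bears a neopentyl group, again with no change beyond the scatter. Nothing at hand explains this flat result.

From the compounds shown here alone, whether a different kind of group at this position, such as an amine or a carboxylic acid, would move the read-out remains open. Also open, going by these compounds, is what would happen if an acetyl group replaced the amino group, or if the (4-chlorophenyl)carbonyl group gave way to a simple benzoyl group.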